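A few compounds are considered here, and "the series" means these few. Any claim that something is new, unique, unknown or untested is made for them only; others in the source may bear on it.

Measured in a functional assay on HCT-116 cells (Homo sapiens) for inhibition, read by sulforhodamine B assay, with a stated time of 2 days; a lower number here means a stronger inhibitor of growth, a higher number a weaker inhibitor of growth:
Compound 1 `CC1=C(C(=O)Nc2ccc(C)cc2)C(c2ccc(O)cc2O)NC(Nc2ccc([N+](=O)[O-])cc2Cl)=N1`: 28200 nM
Compound 2 `CC1=C(C(=O)Nc2cccc([N+](=O)[O-])c2)C(c2ccc(O)cc2O)NC(NCc2ccccc2)=N1`: > 100000 nM, a limit of the assay and not a number
Compound 3 `CC1=C(C(=O)Nc2cccc([N+](=O)[O-])c2)C(c2ccc(O)cc2O)NC(Nc2ccc([N+](=O)[O-])cc2Cl)=N1`: 10900 nM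

Among the two true numbers, compound 3 has the lower one, 10900 nM, and compound 1 is the nearest at 28200 nM. The next compound, compound 4 `CC1=C(C(=O)Nc2cccc([N+](=O)[O-])c2)C(c2ccc(O)cc2O)NC(N/N=C/c2ccco2)=N1`, keeps the rest of compound 3 and differs at one place, on an amine nitrogen: a group of 7 heavy atoms (5 carbon, 1 nitrogen, 1 oxygen; one five-membered aromatic ring with 1 hetero atom) in place of a group of 10 heavy atoms (6 carbon, 1 nitrogen, 2 oxygen, 1 chlorine; one six-membered aromatic ring of carbon only), on an amine nitrogen. The group that enters has no common name.

Two measured steps give some guidance. The one at this same nitrogen is an at least 9.1-fold lower number from compound 2 to compound 3 (0.96 log units; beyond the scatter), where 2-chloro-4-nitrophenyl stands in place of benzyl. It shows that this position can move the read-out, although benzyl is not the group that enters here. The other, a 2.6-fold lower number from compound 1 to compound 3 (0.41 log units; beyond the scatter), lies on the amide-type nitrogen, which does not change in compound 4, so it says little about this step.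

Compound 4 loses the 2-chloro-4-nitrophenyl, so a modest move to a higher number is expected in this assay, with a wide margin. The expected step is a 2.8-fold higher number from compound 3 to compound 4 (0.44 log units; beyond the scatter). For compound 4 the estimated value is 30000 nM, within an estimated range of 9000 nM to 100000 nM.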

Compound 4, concentration for 50% growth inhibition: 8890 nM
For compound 4 the middle estimate is 3.4-fold (0.53 log units) above the measured one; measured number outside the range, below it.
By their numbers in this assay, from the lowest: compounds 4 and 3 (each within the scatter of the next); then compound 1. At a limit, above all of these: compound 2.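

In this assay, the 2-chloro-4-nitrophenyl group on this amine nitrogen turns out not to be needed for the read-out: replacing it with the group carrying a five-membered aromatic ring gives a 1.2-fold lower number from compound 3 to compound 4 (0.09 log units; within the scatter), so compound 3 and compound 4 cannot be told apart. The same entering group, set against benzyl at this nitrogen, gives an at least 11-fold lower number from compound 2 to compound 4 (1.05 log units; beyond the scatter), which shows that two quite different aromatic groups can stand level here while benzyl does not. Compound 2 stands at a limit of the assay and not at a number, so the true size of that step stays open: the limit of > 100000 nM in this assay, at which 1 of the 4 values shown sits.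

The compounds shown leave open which part of the entering group matters, the five-membered aromatic ring or the nitrogen-carbon link that carries it, and whether a longer chain or a plain amine on this nitrogen would stay level with compound 3 and compound 4. They also leave open whether a carboxylic acid on the amide-type nitrogen's aryl group would change the read-out when the entering group is present.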